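This account rests on a few compounds, and the source may have more. Where it says the series, first, only, none or still open, it means among the compounds named here.

Series values in an ADME assay (liver) for metabolic stability, with Liver microsome (Rattus norvegicus) as the target, using microsomes; on this read-out higher numbers stand for fast clearance and lower numbers for slow clearance:
- compound 1 `O=C(O)c1csc(-n2nc(-c3ccc(Cl)cc3)c3ccccc32)n1` gives 753 mL/min/kg
- compound 2 `O=C(O)c1csc(-n2nc(-c3ccsc3)c3ccccc32)n1` gives 190 mL/min/kg

Of the two numbers, compound 2 has the lower one, at 190 mL/min/kg. Compound 3 `O=C(O)c1csc(-n2nc(N3CCCCC3)c3ccccc32)n1` is not yet measured. It differs from compound 2 as follows: piperidin-1-yl in place of thiophen-3-yl on an aromatic carbon. For the measured compounds named here, one measured step bears on this change, a modest one that also swaps the group on an aromatic carbon: a 4.0-fold lower number from compound 1 to compound 2 (0.60 log units; beyond the scatter). That step replaced one aromatic ring with another, so it is only a loose guide to a non-aromatic ring. Going by the values given here, a small rise in this assay is expected, no larger than that step and within the scatter. The expected step is a 1.5-fold higher number from compound 2 to compound 3 (0.17 log units; within the scatter). Compound 3 is estimated at 280 mL/min/kg, with an expected range of 90 mL/min/kg to 750 mL/min/kg.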

Compound 3, clearance: 139 mL/min/kg
The estimate for compound 3 lay 2.0-fold (0.30 log units) above the measured number, and the stated range covers the measured number.
By their numbers in this assay, from the lowest: compounds 3 and 2 (each within the scatter of the next); then compound 1.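

In this assay, a six-membered non-aromatic ring is tolerated at this position: the change from thiophen-3-yl to piperidin-1-yl gives a 1.4-fold lower number from compound 2 to compound 3 (0.14 log units; within the scatter) and so leaves the two compounds within the scatter. Piperidin-1-yl in place of 4-chlorophenyl gives a 5.4-fold lower number from compound 1 to compound 3 (0.73 log units; beyond the scatter) and, with the earlier step, sets 4-chlorophenyl apart from both other groups among these three compounds. Nothing measured here accounts for these steps.

Open, going by these compounds, is whether an unsubstituted phenyl group would sit with 4-chlorophenyl or with the other two groups. Also open, on these data alone, is whether morpholin-4-yl or an open-chain amine such as dimethylamino would stay within the scatter of piperidin-1-yl.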